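Changing the amide aryl group: from compound 3 to compound 4

The source may hold more compounds than are shown below. What is called first, only, known or untested is meant among the compounds shown, and "the series" means these compounds.

Compound 1 `O=C(COc1ccc2cc(/C=C3/SC(=O)NC3=O)ccc2c1)Nc1cccc(Cl)c1`: 3800 nM
Compound 2 `O=C(COc1ccc2cc(/C=C3/SC(=O)NC3=O)ccc2c1)Nc1ccc(Br)c(Br)c1`: 4900 nM
Compound 3 `COc1ccc(NC(=O)COc2ccc3cc(/C=C4/SC(=O)NC4=O)ccc3c2)cc1`: 4700 nM

In an assay on isolated protein for inhibition of histone deacetylase 4 (Homo sapiens), with a stated time of 1 h (a higher number here means a weaker inhibitor, a lower number a stronger inhibitor), compound 3 gives 4700 nM, the second highest of these three numbers; compound 2 sits nearest at 4900 nM and compound 1 furthest at 3800 nM, each within the scatter of compound 3. The steps of a 1.3-fold higher number from compound 1 to compound 2 (0.11 log units; within the scatter), a 1.2-fold higher number from compound 1 to compound 3 (0.09 log units; within the scatter) and a 1.0-fold lower number from compound 2 to compound 3 (0.02 log units; within the scatter) all stay within the scatter, so changing the aryl group on the amide-type nitrogen has so far left the number essentially unchanged. Compound 4 `O=C(COc1ccc2cc(/C=C3/SC(=O)NC3=O)ccc2c1)Nc1cccc(F)n1` differs from compound 3 by 6-fluoropyridin-2-yl in place of 4-methoxyphenyl on an amide-type nitrogen. Those three steps bear on it, and no step beyond the scatter is expected, that is no change at the digits printed from compound 3 to compound 4 (within the scatter). Compound 4 is therefore estimated at 4700 nM, with a range from 2000 nM to 11000 nM.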

Compound 4, half-maximal inhibitory concentration: 840 nM
Estimate against measurement, compound 4: 5.6-fold (0.75 log units) above, and the stated range ends above it.
By their numbers in this assay, from the lowest: compound 4; then compounds 1, 3 and 2 (each within the scatter of the next).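

In this assay the aryl group on the amide-type nitrogen proves able to shift the number: 6-fluoropyridin-2-yl gives a 5.6-fold lower number from compound 3 to compound 4 (0.75 log units; beyond the scatter) and a 5.8-fold lower number from compound 2 to compound 4 (0.77 log units; beyond the scatter) and also a 4.5-fold lower number from compound 1 to compound 4 (0.66 log units; beyond the scatter). Among the compounds shown here, these are the first steps at this position that lie beyond the scatter, so this place is not as indifferent to change as the three phenyl groups suggested. Nothing measured here explains the step. Still open is which part of the new ring matters: would plain pyridin-2-yl, without the fluorine, or a fluorophenyl group keep this lower number?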